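Taking the dimethylamino group off compound 1

The source may report more compounds than this note shows. Statements on the series, on what has been measured and on what is new or still open speak of the compounds shown alone.

In a functional assay on ZR-75-1 cells (Homo sapiens) for inhibition, read by sulforhodamine B assay (on this read-out higher numbers stand for weaker inhibition of growth and lower numbers for stronger inhibition of growth), compound 1 (`Cc1ccc2[nH]c(-c3ccc(-c4ccc(-c5ccc(N(C)C)cc5)cc4)cc3)nc2c1`) gives 7200 nM and stands close to compound 3 (`CN(C)c1ccc(-c2ccc(-c3ccc(-c4nc5c(O)cccc5[nH]4)cc3)cc2)cc1`) at 4100 nM with a 1.8-fold lower number from compound 1 to compound 3 (0.24 log units; within the scatter) between them. Compound 2 (`CN(C)c1ccc(-c2ccc(-c3ccc(-c4nc5ccccc5[nH]4)cc3)cc2)cc1`) reads 100000 nM with a 14-fold higher number from compound 1 to compound 2 (1.14 log units; beyond the scatter) marking the gap. Compound 4 (`Cc1ccc2[nH]c(-c3ccc(-c4ccc(-c5ccccc5)cc4)cc3)nc2c1`) has hydrogen in place of dimethylamino on an aromatic carbon, counted as hydrogen in place of dimethylamino on an aromatic carbon for this change. Among the measured compounds shown here, no measured compound lacks that group, so no measured step bears on it directly. Changes elsewhere can be large, as a 24-fold lower number from compound 2 to compound 3 (1.39 log units; beyond the scatter) shows, but they give neither size nor direction here. The expected change is a 1.4-fold higher number from compound 1 to compound 4 (0.14 log units; within the scatter) and no step beyond the scatter is firmly expected. Compound 4 is estimated at 10000 nM with an expected range from 2500 nM to 50000 nM on this reasoning.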

Compound 4, concentration for 50% growth inhibition: 27400 nM
Compound 4: middle estimate off by 2.7-fold (0.44 log units), on the low side; the range from low to high includes it.
By their numbers in this assay, from the lowest: compounds 3 and 1 (each within the scatter of the next); then compound 4; then compound 2.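

In this assay, the dimethylamino group at this position, para to a large group, is shown to matter, with a 3.8-fold higher number from compound 1 to compound 4 (0.58 log units; beyond the scatter). Its removal weakens growth inhibition modestly but does not abolish it, so the 4-(dimethylamino)phenyl to phenyl change has a real but limited effect on the core of compound 1. No measurement here accounts for this step.

From the compounds shown here alone, whether a smaller amine or a methoxy group at this position would match the dimethylamino group remains open. So does the size of the same removal in compound 2 or compound 3.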